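This account rests on a few compounds, and the source may have more. Where it says the series, first, only, none or still open, it means among the compounds named here.

In a functional assay on U-87MG ATCC cells (Homo sapiens) for cytotoxicity, read by MTT assay, with a stated time of 48 h (a higher number here means a weaker inhibitor, a lower number a stronger inhibitor), compound 1 (`C/C(=N/NC(=S)Nc1ccccc1)c1ccccn1`) gives 1.4 nM and compound 2 (`C/C(=N/NC(=S)Nc1ccc(Cl)cc1)c1ccccn1`) gives 1.7 nM, which places the two together, within the scatter of each other, at the low end of the numbers. Compound 3 (`C/C(=N/NC(=S)Nc1cccc(I)c1)c1ccccn1`) gives 84 nM. Compound 4 (`C/C(=N/NC(=S)Nc1ccccc1[N+](=O)[O-])c1ccccn1`) has nitro in place of hydrogen on an aromatic carbon of compound 1: nitro in place of hydrogen on an aromatic carbon. Two measured steps also replace that kind of hydrogen. The step with chloro, a 1.2-fold higher number from compound 1 to compound 2 (0.08 log units; within the scatter), stays within the scatter, whereas the step with iodo, a 60-fold higher number from compound 1 to compound 3 (1.78 log units; beyond the scatter), is large. Since these two disagree, a moderate rise in the number is expected in this assay, with wide uncertainty. The expected change is a 5.7-fold higher number from compound 1 to compound 4 (0.76 log units; beyond the scatter). For compound 4 the estimated value is 8 nM, with an expected range from 1.5 nM to 60 nM.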

Compound 4, half-maximal inhibitory concentration: 4.3 nM
Compound 4: middle estimate off by 1.9-fold (0.27 log units), on the high side, within the range that was stated.
By their numbers in this assay, from the lowest: compounds 1 and 2 (each within the scatter of the next); then compound 4; then compound 3.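

In this assay, nitro ortho to a large group gives a 3.1-fold higher number from compound 1 to compound 4 (0.49 log units; beyond the scatter), so this replacement of hydrogen on the aromatic ring raises the number only modestly, though beyond the scatter. The step is smaller in size than the large one with iodo, a 60-fold higher number from compound 1 to compound 3 (1.78 log units; beyond the scatter), yet unlike the step with chloro it does not stay within the scatter. Nothing given here accounts for this result. From the compounds shown here alone, whether the rise belongs to this place on the ring or to nitro itself stays open. Also open, going by these compounds, is how an amine or a carboxylic acid on the same carbon would read in this assay.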